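Amide Change at the Carbonyl: Compound 3 to Compound 4

The source may report more compounds than this note shows. Statements on the series, on what has been measured and on what is new or still open speak of the compounds shown alone.

Compound 3 `COc1ccc(Cn2cc(CSC(=S)N3CCN(C(=O)NC(C)C)CC3)nn2)cc1` gives 99200 nM in a functional assay on MGC-803 cells (Homo sapiens) for cytotoxicity, read by MTT assay, with a stated time of 72 h (a lower number here means a stronger inhibitor, a higher number a weaker inhibitor), the highest of the three numbers measured. Among the compounds with values here, compound 1 `CCN(C)C(=O)N1CCN(C(=S)SCc2cn(Cc3ccccc3F)nn2)CC1` gives 5860 nM and compound 2 `CCN(C)C(=O)N1CCN(C(=S)SCc2cn(Cc3ccc(F)cc3)nn2)CC1` gives 1550 nM; the only single-site step measured, a 3.8-fold lower number from compound 1 to compound 2 (0.58 log units; beyond the scatter), sits on the aromatic ring and not at the carbonyl. Compound 4 `CCN(C)C(=O)N1CCN(C(=S)SCc2cn(Cc3ccc(OC)cc3)nn2)CC1` differs from compound 3 by ethyl(methyl)amino in place of isopropylamino on a carbonyl carbon. Within the data shown here, no measured step touches this position, so its effect is unknown; compounds 1 and 2 do carry ethyl(methyl)amino with lower numbers than compound 3, but they also differ in the ring substituent, so that gap cannot be assigned to the amide. The step is estimated as a 5.0-fold lower number from compound 3 to compound 4 (0.70 log units; beyond the scatter), a lowering of uncertain size. Compound 4 is expected at 20000 nM, within 3000 nM to 120000 nM.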

Compound 4, half-maximal inhibitory concentration: 87900 nM
For compound 4 the middle estimate is 4.4-fold (0.64 log units) below the measured one; measured number inside the range.
By their numbers in this assay, from the lowest: compound 2; then compound 1; then compounds 4 and 3 (each within the scatter of the next).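

In this assay, ethyl(methyl)amino in place of isopropylamino on a carbonyl carbon gives a 1.1-fold lower number from compound 3 to compound 4 (0.05 log units; within the scatter) and so, with the 4-methoxyphenyl group present, removes the amide hydrogen donor without a change beyond the scatter. The large steps lie on the aromatic side instead: methoxy in place of fluoro gives a 57-fold higher number from compound 2 to compound 4 (1.75 log units; beyond the scatter) on an aromatic carbon, while 4-methoxyphenyl in place of 2-fluorophenyl gives a 15-fold higher number from compound 1 to compound 4 (1.18 log units; beyond the scatter) in this series. No evidence available here bears on the cause of these steps.

As far as these compounds go, whether this amide change stays within the scatter alongside 4-fluorophenyl or 2-fluorophenyl remains open. Also open, from the compounds shown here alone, is how a longer chain on the carbonyl carbon, such as butylamino, would read.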